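Bromo to methoxy: working notes on the series

This account rests on a few compounds, and the source may have more. Where it says the series, first, only, none or still open, it means among the compounds named here.

- compound 1 `Nc1ccccc1NC(=O)c1ccc(COc2ccc(Br)cc2)cc1`: 24400 nM
- compound 2 `Nc1ccccc1NC(=O)/C=C/c1ccc(COc2ccccc2)cc1`: > 32000 nM (a limit)

Among the measured compounds shown here, in a functional assay on A549 cells (Homo sapiens) for antiproliferative activity, read by CCK-8 assay, with a stated time of 72 h (on this read-out lower numbers stand for stronger inhibition and higher numbers for weaker inhibition), compound 1 gives 24400 nM, the only actual number so far. For compound 2 the value > 32000 nM is a limit, not a number.

Compound 3 `COc1ccc(OCc2ccc(C(=O)Nc3ccccc3N)cc2)cc1` is still unmeasured. It carries methoxy in place of bromo on an aromatic carbon, para to a large group (methoxy in place of bromo on an aromatic carbon). For the measured compounds named here, no measured step covers this change, so no shift beyond the scatter is expected in this assay, in either direction. The estimated step is a 1.1-fold lower number from compound 1 to compound 3 (0.03 log units; within the scatter). Compound 3 is expected at 23000 nM, with an estimated range of 10000 nM to 50000 nM.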

Compound 3, half-maximal inhibitory concentration: 5530 nM
The estimate for compound 3 lay 4.2-fold (0.62 log units) above the measured number; measured number outside the range, below it.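

In this assay, among the compounds shown here, the change from 4-bromophenyl to 4-methoxyphenyl gives a 4.4-fold lower number from compound 1 to compound 3 (0.64 log units; beyond the scatter) and is the first readable step. This position therefore responds to the group it carries, at least for this one pair. Nothing at hand accounts for the shift.

As far as these compounds go, whether the response extends to other groups on this aromatic carbon stays open, for example an amine, a carboxylic acid or a longer alkoxy chain. A single pair also leaves open whether the same change would act alike on another core.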